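Exchanging 4-fluorophenyl for 3,4-dichlorophenyl in compound 3

A few compounds are considered here, and "the series" means these few. Any claim that something is new, unique, unknown or untested is made for them only; others in the source may bear on it.

Compound 1 `COc1ccc(/C=C2\CN(C)C/C(=C\c3ccccc3F)C2=O)cc1` gives 22100 nM
Compound 2 `COc1ccc(/C=C2\CN(C)C/C(=C\c3ccccc3F)C2=O)cc1OC` gives 10500 nM
Compound 3 `COc1cc(/C=C2\CN(C)C/C(=C\c3ccc(F)cc3)C2=O)cc(OC)c1` gives 21900 nM

These numbers come from an ADME assay on L02 cells (Homo sapiens) for cytotoxicity, read by MTT assay, with a stated time of 24 h (a higher number here means a weaker inhibitor, a lower number a stronger inhibitor), and place compound 3 level with compound 1, within the scatter, while compound 2 gives a lower number. The next step leads from compound 3 to compound 4 `COc1cc(/C=C2\CN(C)C/C(=C\c3ccc(Cl)c(Cl)c3)C2=O)cc(OC)c1`, with 3,4-dichlorophenyl in place of 4-fluorophenyl on a double-bonded chain carbon bound to a double-bonded ring carbon. Going by the values given here, the only measured step between close neighbours is a 2.1-fold lower number from compound 1 to compound 2 (0.32 log units; beyond the scatter) for methoxy in place of hydrogen on an aromatic carbon. It is modest and does not involve this exchange, so the data give no direct measure of the change. Going by that single step, only a small move in this assay is expected, no clear step beyond the scatter, with a slight lean towards a lower number. The expected step is a 1.5-fold lower number from compound 3 to compound 4 (0.16 log units; within the scatter) (an estimate only). Compound 4 is expected at 15000 nM with an estimated range from 6500 nM to 33000 nM (not yet measured).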

Compound 4, half-maximal inhibitory concentration: 10600 nM
Beside the measured number, compound 4's estimate is 1.4-fold (0.15 log units) above it; the range from low to high includes it.
By their numbers in this assay, from the lowest: compounds 2 and 4 (each within the scatter of the next); then compounds 3 and 1 (each within the scatter of the next).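

In this assay, going by these compounds alone, the exchange of 4-fluorophenyl for 3,4-dichlorophenyl gives a 2.1-fold lower number from compound 3 to compound 4 (0.32 log units; beyond the scatter) and so provides the first measured step at this position, on a double-bonded chain carbon bound to a double-bonded ring carbon. Within the data shown here, until now the only measured step was a 2.1-fold lower number from compound 1 to compound 2 (0.32 log units; beyond the scatter) for methoxy in place of hydrogen on an aromatic carbon, which left this place without a direct reading. The new step is also modest, but it shows that the number in this assay responds to a change in this aryl group. Nothing measured here accounts for that response. The compounds shown leave open how a plain phenyl or a pyridyl group would read at this place. They also leave open whether 3,4-dichlorophenyl would give a similar step on the core of compound 2.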